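This account rests on a few compounds, and the source may have more. Where it says the series, first, only, none or still open, it means among the compounds named here.

In a functional assay on the whole organism with Rattus norvegicus as the target (on this read-out lower numbers stand for an effect already at smaller amounts and higher numbers for an effect only at larger amounts of compound), compound 1 `CCCOc1ccc([N+](=O)[O-])cc1-c1ncc(-c2nn[nH]n2)c(O)n1` gives 5 mg/kg and compound 2 `CCCOc1ccc(N)cc1-c1ncc(-c2nn[nH]n2)c(O)n1` gives 0.1 mg/kg as the lower of the two numbers. Compound 3 `CCCOc1ccc(N(C)C)cc1-c1ncc(-c2nn[nH]n2)c(O)n1` carries dimethylamino in place of amino on an aromatic carbon. Within the data shown here, the one measured step at this carbon is a 50-fold lower number from compound 1 to compound 2 (1.70 log units; beyond the scatter) and it is large, so a change here can move the number widely. Among the measured compounds shown here, no measured compound carries dimethylamino, so only a moderate move toward a higher number in this assay is expected. The expected step is a 3.0-fold higher number from compound 2 to compound 3 (0.48 log units; beyond the scatter) in this estimate. For compound 3 the estimated value is 0.3 mg/kg with an expected range from 0.05 mg/kg to 2 mg/kg around it.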

Compound 3, dose for 50% inhibition: 0.4 mg/kg
The estimate for compound 3 lay 1.3-fold (0.12 log units) below the measured number, and the stated range covers the measured number.
By their numbers in this assay, from the lowest: compound 2; then compound 3; then compound 1.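

In this assay, dimethylamino, which has no hydrogen-bond donor, is tolerated at this carbon with only a modest loss: a 4.0-fold higher number from compound 2 to compound 3 (0.60 log units; beyond the scatter). The low numbers are therefore not confined to amino, and dimethylamino also keeps most of the gain over nitro, with a 13-fold lower number from compound 1 to compound 3 (1.10 log units; beyond the scatter). Nothing available explains either step. Going by these compounds, it remains open whether methylamino would read closer to compound 2 or compound 3, and how an acetamide or a carboxylic acid on this carbon would compare.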